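The compounds below may be only part of what the source reports. "The series", "measured", "known", "first", "only" and "open" are said of these compounds alone.

Compound 1 `CCOC(=O)c1c(-c2cccc(-c3ccccc3)c2)[nH]c2cc(OC)ccc2c1=O` was measured in an ADME assay on HEK293 cells (Homo sapiens) for cytotoxicity, read by luminescence, with a stated time of 72 h; on this read-out lower numbers stand for an effect already at smaller amounts and higher numbers for an effect only at larger amounts of compound. In this assay compound 1 gives > 22000 nM, which is a limit of the assay and not a number.
Compound 2 `CCOC(=O)c1c(-c2cccc(OC)c2)[nH]c2cc(OC)ccc2c1=O` was measured in the same way. In this assay compound 2 gives > 22000 nM, again a limit rather than a number.
Compound 3 `CCOC(=O)c1c(-c2cccc(-c3ccccc3)c2)[nH]c2cc(Cl)c(OC)cc2c1=O` completes the measured set. In this assay compound 3 gives > 22000 nM, also a limit and not a number.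

From compound 1 to compound 2 the change is methoxy in place of phenyl on an aromatic carbon, and the step it made in this assay is a step that the two limits leave unreadable from compound 1 to compound 2. Because both ends of that step sit at the limit of > 22000 nM in this assay, at which 3 of the 3 values shown sit, its size cannot be read.

The core of compound 3 differs from the core of compound 1 in more than one place, and the difference between the two cores is not broken down here.

Compound 4 `CCOC(=O)c1c(-c2cccc(OC)c2)[nH]c2cc(Cl)c(OC)cc2c1=O` has not yet been measured. It differs from compound 3 by methoxy in place of phenyl on an aromatic carbon, the same change that separates compound 1 from compound 2, since the two places are described in identical words.

For compound 4 in this assay a step that the limit leaves unreadable from compound 3 to compound 4 from compound 3 is expected, a size that rests only on compound 3 sitting at the limit of > 22000 nM in this assay, at which 3 of the 3 values shown sit, and on the matching pair, compound 1 and compound 2, both sitting at that same limit. The estimate for compound 4 is 30000 nM, with an expected range from 15000 nM to 80000 nM, and the most likely outcome is that this assay again reports only a limit for compound 4.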

Compound 4, half-maximal effective concentration: > 22000 nM
Compound 4: a limit, no number (the forecaster's own chance of this, stated with the estimate: 85%); the middle value does not contradict the limit.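

In this assay compound 4 gives > 22000 nM, which is a limit and not a number. No size can be read for the step between compound 3 and compound 4, because both ends sit at the same limit: the limit of > 22000 nM in this assay, at which 4 of the 4 values shown sit.

The compounds shown leave open whether methoxy in place of phenyl, or the difference between the core of compound 1 and the core of compound 3, changes the read-out in this assay at all.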